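The source may hold more compounds than are shown below. What is called first, only, known or untested is meant among the compounds shown, and "the series" means these compounds.

Compound 1 `Cc1cccc2c(NCc3ccco3)nc(NC(C)C)nc12`, compound 2 `Cc1ccc2c(NCc3ccco3)nc(NC(C)C)nc2c1` and compound 3 `COc1cccc2c(NCc3ccco3)nc(NC(C)C)nc12` share a core, and each has been measured in a physicochemical assay for solubility, at pH 7.4; a lower number here means a less soluble compound, a higher number a more soluble compound. In this assay compound 1 gives <= 20000 nM, which is a limit of the assay rather than a number. Compound 2 likewise gives <= 20000 nM, again a limit. Compound 3 gives <= 20000 nM, also a limit. The difference between the cores of compound 1 and compound 2 is not broken down here. From compound 1 to compound 3 the change is methoxy in place of methyl on an aromatic carbon, and the step that the two limits leave unreadable from compound 1 to compound 3 is unreadable because of the limit of <= 20000 nM in this assay, at which 3 of the 3 values shown sit. Compound 4 `COc1ccc2c(NCc3ccco3)nc(NC(C)C)nc2c1` has not yet been measured; it differs from compound 2 by methoxy in place of methyl on an aromatic carbon. This is the same kind of change as that from compound 1 to compound 3, though the place differs: in compound 3 the methoxy is ortho to a fused ring and meta to a fused ring, whereas in compound 4 it is meta to a fused ring and para to a fused ring. Since the three measured compounds all sit at a limit, the step of a number no lower from compound 2 to compound 4 (the limit leaves the size open) is expected to be small, and compound 4 is expected to give about 20000 nM, between 8000 nM and 20000 nM.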

Compound 4, solubility: <= 20000 nM
Compound 4 ended at the assay's limit; the forecaster's own chance of this, stated with the estimate: 80%; the middle value sits exactly at the limit.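

In this assay no step can be read from compound 2 to compound 4, because both compounds sit at a limit and not at a number: the limit of <= 20000 nM in this assay, at which 4 of the 4 values shown sit.

The compounds shown leave open how soluble compound 1, compound 2, compound 3 and compound 4 actually are, and whether methoxy in place of methyl changes that at either place.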